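Trading Ethylamino for Chloro: What to Expect

The source may hold more compounds than are shown below. What is called first, only, known or untested is meant among the compounds shown, and "the series" means these compounds.

Of the compounds shown here, three sharing one core have been measured in an assay on cells for inhibition of MAP kinase-interacting serine/threonine-protein kinase 1 (Homo sapiens), read by mobility shift assay, with stated times of 10 min and 60 min, in the presence of a further agent that is not named here; a higher number here means a weaker inhibitor, a lower number a stronger inhibitor. Compound 1 `CCOc1cc(-c2cccnc2)ccc1C(N)=O` gives 2200 nM. Compound 2 `CC(=O)c1cncc(-c2ccc(C(N)=O)cc2)c1` gives 8000 nM. Compound 3 `CCNc1cc(-c2cccnc2)ccc1C(N)=O` gives 58000 nM, the highest of the three numbers, which makes it the weakest inhibitor of the set; the nearest of the others is compound 2 and the furthest is compound 1. Within the data shown here, the one measured change that leads directly to compound 3 is a 26-fold higher number from compound 1 to compound 3 (1.42 log units; beyond the scatter), a large step.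

Compound 4 `NC(=O)c1ccc(-c2cccnc2)cc1Cl` differs from compound 3 in a single spot: chloro in place of ethylamino on an aromatic carbon. Among the measured compounds shown here, no measured step swaps an ethylamino for a chloro, so the only guide is the step of a 26-fold higher number from compound 1 to compound 3 (1.42 log units; beyond the scatter), which shows that placing ethylamino in this spot raised the number sharply. As far as these compounds go, removing it again is therefore expected to lower the number, though how closely chloro behaves like ethoxy here is unknown. Compound 4 is thus expected to give about 5000 nM, within a range of 1000 nM to 25000 nM. That estimate means an expected 12-fold lower number from compound 3 to compound 4 (1.06 log units; beyond the scatter), resting on the size of the step of a 26-fold higher number from compound 1 to compound 3 (1.42 log units; beyond the scatter).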

Compound 4, half-maximal inhibitory concentration: 11000 nM
Beside the measured number, compound 4's estimate is 2.2-fold (0.34 log units) below it; measured number inside the range.
By their numbers in this assay, from the lowest: compound 1; then compounds 2 and 4 (each within the scatter of the next); then compound 3.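

In this assay, putting chloro in place of ethylamino, ortho to a carbamoyl group, gives a 5.3-fold lower number from compound 3 to compound 4 (0.72 log units; beyond the scatter) and so wins back part of what ethylamino cost. Chloro still does not match ethoxy, as the comparison shows a 5.0-fold higher number from compound 1 to compound 4 (0.70 log units; beyond the scatter) for the same spot. This position therefore separates all three groups, with ethoxy giving the lowest number, chloro the middle one and ethylamino the highest, and every gap lies beyond the usual scatter, so the outcome here depends on which group is chosen and not merely on ethylamino being gone.

As far as these compounds go, whether methoxy, fluoro or a longer chain such as propoxy would land nearer ethoxy or nearer chloro remains open. Nothing available here explains why the three groups rank in this order.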